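Methyl for trifluoromethyl on a hydroxyquinoline sulfone

The source may report more compounds than this note shows. Statements on the series, on what has been measured and on what is new or still open speak of the compounds shown alone.

The series rests on a shared core carrying a hydroxy group and a sulfone. Compound 1 `O=S(=O)(c1ccc(O)c2ncccc12)C1CCCC1` belongs to it, yet in an ADME assay on cells (Hepatocyte, Rattus norvegicus) for pharmacokinetics (a higher number here means faster removal of the compound, a lower number slower removal), compound 1 gives "not determined" (no result reported), so it gives no number to compare. Among the compounds with values here, compound 2 `O=S(=O)(c1ccc(C(F)(F)F)cc1)c1cc(F)c(O)c2ncccc12` is therefore the only member with a measured value: in this assay compound 2 gives 12 uL/min, and it stands alone as the single reference point, with compound 1 contributing no figure.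

Compound 3 `Cc1ccc(S(=O)(=O)c2cc(F)c(O)c3ncccc23)cc1` has not yet been run in this assay. It differs from compound 2 in one place: methyl in place of trifluoromethyl on an aromatic carbon. Within the data shown here, no pair of measured compounds shows how such a change plays out here, so nothing in the data fixes the direction of the step.

On that basis the author expects the step from compound 2 to compound 3 in this assay to be small, a 1.5-fold higher number from compound 2 to compound 3 (0.18 log units; within the scatter), leaning toward faster removal but likely not beyond the usual scatter. For compound 3 the estimate is 18 uL/min, with a range from 8 uL/min to 45 uL/min.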

Compound 3, intrinsic clearance in a liver preparation (reported as CLH), per the amount of preparation that the assay uses: 36 uL/min
For compound 3 the middle estimate is 2.0-fold (0.30 log units) below the measured one; low and high end bracket the measured number.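

In this assay, the exchange of trifluoromethyl for methyl on an aromatic carbon, para to a large group, now has a measured size: a 3.0-fold higher number from compound 2 to compound 3 (0.48 log units; beyond the scatter). Within the data shown here, this is the first pair of measured compounds that differ in one place, and it shows that the group at this carbon matters in this assay, with the methyl compound removed faster than its trifluoromethyl partner. No accompanying measurement speaks to the origin of this step, so it stands as an observation only.

The compounds shown leave open whether the step is particular to this pair of groups or part of a wider trend at this carbon, which a chlorine atom, a methoxy group or a nitrile in the same place could help to settle. Also open, going by these compounds, is whether a plain hydrogen at this carbon would give a number closer to that of compound 2 or to that of compound 3, and whether the same exchange would give a step of similar size on a core carrying a different sulfone partner.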